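A few compounds are considered here, and "the series" means these few. Any claim that something is new, unique, unknown or untested is made for them only; others in the source may bear on it.

Measured in a functional assay on MCF7 cells (Homo sapiens) for inhibition, read by MTT assay, with a stated time of 72 h; on this read-out lower numbers stand for stronger inhibition and higher numbers for weaker inhibition:
- compound 1 `Cc1ccc(-n2c(-c3coc4cc(C)c(Cl)cc4c3=O)nc(-c3ccccc3)c2-c2ccccc2)c(C)c1`: 6250 nM
- compound 2 `Cc1cc2occ(-c3nc(-c4ccccc4)c(-c4ccccc4)n3-c3ccc(Cl)cc3)c(=O)c2cc1Cl`: 12500 nM
- compound 3 `Cc1cc2occ(-c3nc(-c4ccccc4)c(-c4ccccc4)n3-c3cccc([N+](=O)[O-])c3)c(=O)c2cc1Cl`: 1560 nM

Compound 3 has the lowest number of the three, as shown by a 4.0-fold lower number from compound 1 to compound 3 (0.60 log units; beyond the scatter) and by an 8.0-fold lower number from compound 2 to compound 3 (0.90 log units; beyond the scatter). Compound 4 `Cc1ccc(-n2c(-c3coc4cc(C)c(Cl)cc4c3=O)nc(-c3ccccc3)c2-c2ccccc2)cc1` carries 4-methylphenyl in place of 3-nitrophenyl on an aromatic nitrogen. The group that enters resembles 2,4-dimethylphenyl and 4-chlorophenyl, the groups of the two compared compounds, which themselves show a 2.0-fold higher number from compound 1 to compound 2 (0.30 log units; within the scatter). Those steps, read backwards, point to a rise of similar size in this assay. The expected change is a 4.2-fold higher number from compound 3 to compound 4 (0.62 log units; beyond the scatter). For compound 4 the estimated value is 6500 nM, with an expected range of 2500 nM to 15000 nM.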

Compound 4, half-maximal inhibitory concentration: 12500 nM
Beside the measured number, compound 4's estimate is 1.9-fold (0.28 log units) below it; low and high end bracket the measured number.
By their numbers in this assay, from the lowest: compound 3; then compounds 1, 2 and 4 (each within the scatter of the next).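

In this assay, 4-methylphenyl in place of 3-nitrophenyl on the aromatic nitrogen gives an 8.0-fold higher number from compound 3 to compound 4 (0.90 log units; beyond the scatter), so compound 3 now stands apart from three compounds with other groups at this position. Those three stay within the scatter of one another, with no change at the digits printed from compound 2 to compound 4 (within the scatter) for methyl in place of chloro and a 2.0-fold higher number from compound 1 to compound 4 (0.30 log units; within the scatter) for hydrogen in place of methyl. Nothing shown here explains why the 3-nitrophenyl group stands apart. Going by these compounds, whether 4-nitrophenyl, or a phenyl ring carrying an amine or a carboxylic acid, would match compound 3 remains open.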